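Methyl to Methoxy on the Pendant Phenyl: Expected Effect

The source may hold more compounds than are shown below. What is called first, only, known or untested is meant among the compounds shown, and "the series" means these compounds.

Measured compounds in a functional assay on SGC-7901 cells (Homo sapiens) for antiproliferative activity, read by MTT assay, with a stated time of 72 h; on this read-out higher numbers stand for weaker inhibition and lower numbers for stronger inhibition:
- compound 1, `COc1ccccc1-c1ccc2ncn(-c3cc(OC)c(OC)c(OC)c3)c2c1`: 5050 nM
- compound 2, `COc1cc(-n2cnc3ccc(-c4cccc(Cl)c4)cc32)cc(OC)c1OC`: 1490 nM
- compound 3, `COc1cc(-n2cnc3ccc(-c4cccc(C)c4)cc32)cc(OC)c1OC`: 1240 nM

All three share one core and differ only in the aryl group attached to it. Compound 3 gives the lowest number of the three, but its gap to compound 2 is small: a 1.2-fold lower number from compound 2 to compound 3 (0.08 log units; within the scatter). Against compound 1 the gap is clearer: a 4.1-fold lower number from compound 1 to compound 3 (0.61 log units; beyond the scatter), and the matching change to compound 2 gave a 3.4-fold lower number from compound 1 to compound 2 (0.53 log units; beyond the scatter).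

Compound 4, `COc1cccc(-c2ccc3ncn(-c4cc(OC)c(OC)c(OC)c4)c3c2)c1`, has not yet been measured in this assay. Its structure differs from compound 3 in one place: methoxy in place of methyl on an aromatic carbon.

Among the compounds with values here, only one measured step touches the same place on the phenyl ring, the swap from chloro to methyl between compound 2 and compound 3, and that step stayed within the scatter. Within the data shown here, no measured pair exchanges methyl for methoxy, so there is no direct precedent for that change. The two larger steps, from compound 1, concern a different phenyl altogether and do not speak to this swap.

On that basis compound 4 is expected to stay close to compound 3, with a step of about a 1.2-fold higher number from compound 3 to compound 4 (0.08 log units; within the scatter), and an estimated value of 1500 nM, within a range from 600 nM to 4000 nM.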

Compound 4, half-maximal inhibitory concentration: 3310 nM
Estimate against measurement, compound 4: 2.2-fold (0.34 log units) below; the measured number falls inside the stated range.
By their numbers in this assay, from the lowest: compounds 3 and 2 (each within the scatter of the next); then compounds 4 and 1 (each within the scatter of the next).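

Within the data shown here, the methoxy group is the first at this place on the phenyl ring to separate from the others: replacing methyl raised the number (a 2.7-fold higher number from compound 3 to compound 4 (0.43 log units; beyond the scatter)), and so did replacing chloro (a 2.2-fold higher number from compound 2 to compound 4 (0.35 log units; beyond the scatter)), both beyond the scatter, whereas chloro and methyl had stayed within the scatter of each other. So a change as small as one added oxygen, which brings one hydrogen-bond acceptor by the count, is enough to shift the result here, while moving the methoxy to the other place on the phenyl ring gives a difference too small to read (a 1.5-fold lower number from compound 1 to compound 4 (0.18 log units; within the scatter)), within the scatter. No measurement among these compounds speaks to the reason for the shift.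

On these data alone, it remains open whether a hydroxyl, an amine or a longer chain such as ethoxy at this place would fall with methyl and chloro or with methoxy. Methyl and chloro each appear at only one place on the phenyl ring, so whether moving either of them would matter more than moving methoxy also stays unanswered.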